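The source may hold more compounds than are shown below. What is called first, only, known or untested is meant among the compounds shown, and "the series" means these compounds.

Three compounds share one core and differ only in what sits on an amide-type nitrogen. Compound 1 `COc1ccc(-n2nc(C(N)=O)nc2-c2cc(OC)c(OC)c(OC)c2)cc1` carries hydrogen there, and in a functional assay on the whole organism for inhibition, with Rattus norvegicus as the target, read by paw edema, with stated times of 30 min and 3 h, at a dose of 0.28 mmol/kg by the oral route (a higher number here means more inhibition at the dose given (going by the name of the read-out), a lower number less inhibition), compound 1 gives 106%. Compound 2 `COc1ccc(-n2nc(C(=O)Nc3ccccc3C)nc2-c2cc(OC)c(OC)c(OC)c2)cc1` carries 2-methylphenyl, and in this assay compound 2 gives 74%, a drop of a number 32 percentage points lower from compound 1 to compound 2 (beyond the scatter). Compound 3 `COc1ccc(-n2nc(C(=O)Nc3cccc(F)c3)nc2-c2cc(OC)c(OC)c(OC)c2)cc1` carries 3-fluorophenyl, and in this assay compound 3 gives 106%, which is no change at the digits printed from compound 1 to compound 3 (within the scatter) and a number 32 percentage points higher from compound 2 to compound 3 (beyond the scatter). Compound 3 thus stands level with compound 1 at the top of the three numbers, and well apart from compound 2.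

Compound 4 `COc1ccc(-n2nc(C(=O)Nc3ccc(C(=O)O)cc3)nc2-c2cc(OC)c(OC)c(OC)c2)cc1` makes the change (4-carboxyphenyl in place of 3-fluorophenyl on an amide-type nitrogen). Two earlier steps put an aryl group on this nitrogen: one left the number unchanged, the other lowered it strongly. Within the data shown here, no measured step carries a carboxyphenyl, so the direction is uncertain. The expected step from compound 3 to compound 4 in this assay is a number 16 percentage points lower from compound 3 to compound 4 (beyond the scatter), a modest loss within the range the two aryl examples span. Compound 4 is therefore estimated at 90%, between 60% and 110%.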

Compound 4, a percentage reported as inhibition, in the whole organism at one dose (the size of the read-out at that dose, not a potency): 109%
The estimate for compound 4 lay 19 percentage points below the measured number; measured number inside the range.
By their numbers in this assay, from the lowest: compound 2; then compounds 1, 3 and 4 (each within the scatter of the next).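

In this assay, replacing 3-fluorophenyl with 4-carboxyphenyl gives a number 3 percentage points higher from compound 3 to compound 4 (within the scatter), and the comparison with the hydrogen of compound 1 gives a number 3 percentage points higher from compound 1 to compound 4 (within the scatter). A second aryl group on the amide-type nitrogen therefore matches hydrogen, even though it carries a carboxylic acid and 3-fluorophenyl does not. The step from the 2-methylphenyl group gives a number 35 percentage points higher from compound 2 to compound 4 (beyond the scatter), leaving compound 2 as the only one of the four that goes against this match, and nothing measured here accounts for that difference.

A 3-methylphenyl or 2-fluorophenyl group on this nitrogen would help show whether the methyl group itself or its place on the ring goes with the low number of compound 2. On these data alone, how a 4-aminophenyl group or a longer alkyl chain would fare at this position remains open.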